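The source may hold more compounds than are shown below. What is called first, only, known or untested is meant among the compounds shown, and "the series" means these compounds.

The measured compounds:
Compound 1 `CC(=O)O[C@H]1CC[C@]2(C)[C@H](CC[C@@](C)(O)[C@H]2CC[C@@H]2C(C)=CC[C@H]3[C@H](CC[C@]3(C)O)C2(C)C)OC1(C)C`: 38000 nM in a functional assay on MDA-MB-231 cells (Homo sapiens) for antiproliferative activity, read by MTT assay, with a stated time of 72 h; a higher number here means a weaker inhibitor, a lower number a stronger inhibitor
Compound 2 `CC(=O)O[C@H]1CC[C@]2(C)[C@H](CC[C@@](C)(O)[C@H]2CC[C@@H]2C(C)=CC[C@H]3[C@H](CC[C@]3(C)OC(C)=O)C2(C)C)OC1(C)C`: 26200 nM
Compound 3 `CC1=CC[C@H]2[C@H](CC[C@]2(C)O)C(C)(C)[C@@H]1CC[C@H]1[C@]2(C)CC/C(=N/OCc3ccccc3)C(C)(C)O[C@H]2CC[C@@]1(C)O`: 38200 nM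

Among these three numbers compound 1 holds the second highest. Compound 3 gives a number that is, to all purposes, the same as that of compound 1, and compound 2 is also within the scatter, its step being a 1.5-fold lower number from compound 1 to compound 2 (0.16 log units; within the scatter), an acetyl in place of hydrogen on an oxygen on a saturated carbon. For the measured compounds named here, that is the only single-site step in the set, and it sits on a different part of the shared core.

Compound 4 `CC1=CC[C@H]2[C@H](CC[C@]2(C)O)C(C)(C)[C@@H]1CC[C@H]1[C@]2(C)CC[C@H](OC(=O)c3ccc(C(F)(F)F)c(F)c3)C(C)(C)O[C@H]2CC[C@@]1(C)O` differs from compound 1 in one place: 3-fluoro-4-(trifluoromethyl)phenyl in place of methyl on a carbonyl carbon. Going by the values given here, no measured step touches this carbonyl carbon, so no step in hand bears directly on the change; the one comparable step, from compound 1 to compound 2, stayed within the scatter. On that basis compound 4 is expected to give a number near that of compound 1, with the estimate leaning a little lower, a step of a 1.7-fold lower number from compound 1 to compound 4 (0.24 log units; within the scatter). The estimate for compound 4 in this assay is 22000 nM, in a range from 6000 nM to 60000 nM.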

Compound 4, half-maximal inhibitory concentration: 22200 nM
Compound 4: the middle estimate sits 1.0-fold (0.00 log units) below what was measured; the measured number falls inside the stated range.
By their numbers in this assay, from the lowest: compounds 4, 2, 1 and 3 (each within the scatter of the next).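

On the carbonyl carbon of compound 1, the methyl gives way to 3-fluoro-4-(trifluoromethyl)phenyl, with 11 heavy atoms entering for 1 and a six-membered aromatic ring added. In this assay this is a 1.7-fold lower number from compound 1 to compound 4 (0.23 log units; within the scatter), so this position takes a much larger aromatic group without a change beyond the scatter, something the earlier step, made at a different site, could not show. Nothing available here explains this outcome.

The aromatic ring and the fluorine atoms enter together in this one step, so the compounds shown do not separate what each contributes. Going by these compounds, what an unsubstituted phenyl, a longer alkyl chain or a group carrying an amine or a carboxylic acid would give on this carbonyl carbon stays open.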